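Bromo to methyl: a small step expected

The source may hold more compounds than are shown below. What is called first, only, known or untested is meant among the compounds shown, and "the series" means these compounds.

In a functional assay on P388 cells (Mus musculus) for inhibition (a higher number here means a weaker inhibitor, a lower number a stronger inhibitor), compound 1 `O=C1/C(=C/c2cccc(Cl)c2)CCCc2ccccc21` gives 8200 nM and compound 2 `O=C1/C(=C/c2cccc(Br)c2)CCCc2ccccc21` gives 10500 nM. These two compounds differ only in bromo in place of chloro on an aromatic carbon, and that exchange gives a 1.3-fold higher number from compound 1 to compound 2 (0.11 log units; within the scatter). Compound 2 therefore stands level with compound 1, and neither can be called the better inhibitor.

Compound 3 `Cc1cccc(/C=C2\CCCc3ccccc3C2=O)c1` has not yet been measured. It keeps the shared core of compound 2 and makes a single change: methyl in place of bromo on an aromatic carbon. This puts methyl in place of bromo on an aromatic carbon, meta to a large group.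

Within the data shown here, only one measured step bears on this change, and it is a loose guide, since no measured compound carries methyl. Compound 2 at 10500 nM is the starting point, and the exchange that produced it gave only a 1.3-fold higher number from compound 1 to compound 2 (0.11 log units; within the scatter), so no step beyond the scatter is expected in this assay. The estimated change is a 1.1-fold lower number from compound 2 to compound 3 (0.02 log units; within the scatter). Compound 3 is expected at 10000 nM, with an estimated range of 4000 nM to 25000 nM.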

Compound 3, half-maximal inhibitory concentration: 19900 nM
Compound 3: the middle estimate sits 2.0-fold (0.30 log units) below what was measured; the measured number falls inside the stated range.
By their numbers in this assay, from the lowest: compounds 1, 2 and 3 (each within the scatter of the next, the first and the last beyond it).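

Among these compounds, on this aromatic carbon, methyl gives the first step in this assay that clears the scatter: in place of chloro it gives a 2.4-fold higher number from compound 1 to compound 3 (0.39 log units; beyond the scatter), a modest loss of inhibition. Methyl in place of bromo gives a 1.9-fold higher number from compound 2 to compound 3 (0.28 log units; within the scatter), which stays within the scatter, so compound 2 and compound 3 cannot be ranked, and methyl separates clearly only from chloro, while bromo separates clearly from neither of the other two groups. Nothing available here accounts for this small difference between methyl and chloro.

From the compounds shown here alone, these three compounds cover only chloro, bromo and methyl, so it remains open whether a different kind of group at this place, such as an amine, a carboxylic acid or a longer chain, would stay within this narrow span or move well outside it. Going by these compounds, all three also carry their group at the same place on the ring, so it is unknown what these groups would do elsewhere on it, or whether any change could give a clearly stronger inhibitor than compound 1 at 8200 nM.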